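The source may hold more compounds than are shown below. What is called first, only, known or untested is meant among the compounds shown, and "the series" means these compounds.

Three compounds in this series share one core and differ in the aryl group attached to the nitrogen on the aromatic ring. Compound 1 `CCc1cccc(Nc2cc(NC(=O)Nc3cc(OC)cc(OC)c3)ncn2)c1` gives in a functional assay on HCC827 cells (Homo sapiens) for inhibition, read by MTT assay, with a stated time of 48 h, tested at 10 uM (on this read-out higher numbers stand for more inhibition at the one concentration tested (going by the name of the read-out) and lower numbers for less inhibition), a reading of 52.6%. Compound 2 `COc1cc(NC(=O)Nc2cc(Nc3cccc(C(C)(C)C)c3)ncn2)cc(OC)c1` gives in this assay a reading of 48.7%, and compound 3 `COc1cc(NC(=O)Nc2cc(Nc3ccc(OC)c(I)c3)ncn2)cc(OC)c1` gives in this assay a reading of 61.7%. Compound 2 stands at the lowest of the three numbers: the change from compound 1 to compound 2, tert-butyl in place of ethyl on an aromatic carbon, gives a number 3.9 percentage points lower from compound 1 to compound 2 (within the scatter), while the change to compound 3 gives a number 13 percentage points higher from compound 2 to compound 3 (beyond the scatter).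

Compound 4 `CC(C)(C)c1cccc(Nc2cc(NC(=O)Nc3c(Cl)cccc3Cl)ncn2)c1` is built from compound 2 by a change at a different place: 2,6-dichlorophenyl in place of 3,5-dimethoxyphenyl on an amide-type nitrogen. Among the compounds with values here, none of the measured steps touches the aryl group on the amide-type nitrogen; all of them, including a number 9.1 percentage points higher from compound 1 to compound 3 (within the scatter), alter only the group on the nitrogen of the aromatic ring, and those steps ranged from within the scatter to modest. There is therefore no measured guide to this change, and compound 4 is expected to stay close to compound 2, with a number 3.7 percentage points lower from compound 2 to compound 4 (within the scatter) expected to be no step beyond the scatter. Compound 4 is accordingly estimated at 45%, in a range from 25% to 65%.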

Compound 4, a percentage reported as inhibition, at one concentration (the size of the read-out at that concentration, not a potency): 37.3%
The estimate for compound 4 lay 7.7 percentage points above the measured number; measured number inside the range.
By their numbers in this assay, from the lowest: compound 4; then compounds 2, 1 and 3 (each within the scatter of the next, the first and the last beyond it).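

Within the data shown here, the aryl group on the amide-type nitrogen, which no earlier step had touched, proves able to move the reading in this assay: 2,6-dichlorophenyl in place of 3,5-dimethoxyphenyl gives a number 11.4 percentage points lower from compound 2 to compound 4 (beyond the scatter). Among these compounds, this step is of modest size, as is the one at the group on the nitrogen of the aromatic ring, a number 13 percentage points higher from compound 2 to compound 3 (beyond the scatter), so on this small set a change at either place can carry the reading beyond the scatter, and here the direction is downward. The change swaps a group with 2 hydrogen-bond acceptors for one with 0 and methoxy groups for chlorine atoms all at once, and nothing available explains the lower reading.

As far as these compounds go, it remains open whether the same exchange would lower the reading on the frameworks of compound 1 and compound 3, since this single pair rests on the 3-(tert-butyl)phenyl group alone. Also open, from the compounds shown here alone, is how the reading would respond to other groups on the amide-type nitrogen, such as an unsubstituted phenyl ring, a phenyl ring bearing a single chlorine atom, or one bearing a carboxylic acid.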